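Swapping Trifluoromethyl for Phenyl on a Shared Core

A few compounds are considered here, and "the series" means these few. Any claim that something is new, unique, unknown or untested is made for them only; others in the source may bear on it.

Going by the values given here, compound 2 `COc1cc(-c2nnc3n2NC(c2ccco2)C(C(=O)c2ccc(C(F)(F)F)cc2)S3)cc(OC)c1OC` gives 33600 nM in a functional assay on MCF7 cells (Homo sapiens) for cytotoxicity, read by MTT assay, with a stated time of 48 h (on this read-out lower numbers stand for stronger inhibition and higher numbers for weaker inhibition), the only plain number among the values shown. Compound 1 `COc1cc(-c2nnc3n2NC(c2ccco2)C(C(=O)c2ccc(F)cc2)S3)cc(OC)c1OC` gives only a limit, > 100000 nM. Among the compounds with values here, the single measured step, an at least 2.9-fold lower number from compound 1 to compound 2 (0.47 log units; beyond the scatter), is the one that bears on the change that follows, and it rests on a limit at one end, (the limit of > 100000 nM in this assay, at which 1 of the 2 values shown sits). Compound 3 `COc1cc(-c2nnc3n2NC(c2ccco2)C(C(=O)c2ccc(-c4ccccc4)cc2)S3)cc(OC)c1OC` carries phenyl in place of trifluoromethyl on an aromatic carbon. One step offers thin guidance, so a modest move downward, with wide uncertainty, is expected. Compound 3 is expected to give 20000 nM, between 5000 nM and 80000 nM. The expected step is a 1.7-fold lower number from compound 2 to compound 3 (0.23 log units; within the scatter).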

Compound 3, half-maximal inhibitory concentration: > 100000 nM
Compound 3 gave a limit, no number; the forecaster's own chance of this, stated with the estimate: 15%; middle value at least 5.0-fold (0.69 log units) from the limit.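

Replacing trifluoromethyl with phenyl on the aromatic ring gives an at least 2.9-fold higher number from compound 2 to compound 3 (0.47 log units; beyond the scatter) in this assay, so the gain that trifluoromethyl showed over fluoro does not carry over to phenyl. Of the three groups at this position, only trifluoromethyl gives a plain number, while the other two compounds sit at one limit: the limit of > 100000 nM in this assay, at which 2 of the 3 values shown sit. The step from compound 1 to compound 3 cannot be read, as both values are limits.

As far as these compounds go, whether a methoxy group, a chlorine atom or an amine at this position would give a lower number remains open.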